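The compounds below may be only part of what the source reports. "The series", "measured", "known", "first", "only" and "open" are said of these compounds alone.

Compound 1 `C/C(=N\NC(=S)Nc1ccc(I)cc1)c1ccccn1`: 64 nM
Compound 2 `C/C(=N\NC(=S)Nc1ccccc1)c1ccccn1`: 6.81 nM

Both values come from a functional assay on T98G cells (Homo sapiens) for cytotoxicity, read by MTT assay, with a stated time of 48 h; on this read-out lower numbers stand for stronger inhibition and higher numbers for weaker inhibition. Compound 1 has the higher of the two numbers, so it is the weaker inhibitor of the pair, and the gap is a 9.4-fold lower number from compound 1 to compound 2 (0.97 log units; beyond the scatter). That step puts hydrogen in place of iodo on an aromatic carbon.

Compound 3 `C/C(=N/NC(=S)Nc1ccc(I)cc1)c1ccccn1` keeps the iodo group of compound 1 and differs in another way: the two compounds have the same atoms and bonds and differ only in configuration as drawn: 1 of 1 stereo elements differ; a double bond is drawn E in compound 1 and Z in compound 3. The two compounds have the same atoms and bonds, and a double bond is drawn E in compound 1 and Z in compound 3.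

Going by the values given here, no measured pair changes this double bond, so the data give no direction for such a change. Among the compounds with values here, the one measured step shows only that a single change can move the number beyond the scatter, and it concerns a different kind of change. The central expectation in this assay is therefore no step beyond the scatter, with wide uncertainty on both sides.

The estimate for compound 3 is an expected 60 nM, with an expected range of 12 nM to 280 nM. This estimate means an expected 1.1-fold lower number from compound 1 to compound 3 (0.03 log units; within the scatter).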

Compound 3, half-maximal inhibitory concentration: 64 nM
Beside the measured number, compound 3's estimate is 1.1-fold (0.03 log units) below it; measured number inside the range.
By their numbers in this assay, from the lowest: compound 2; then compounds 1 and 3 (each within the scatter of the next).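

Going by these compounds alone, until now the only measured step was hydrogen in place of iodo on an aromatic carbon. Within the data shown here, this pair is the first to test the double bond itself, and in this assay going from the E to the Z drawing gives no change at the digits printed from compound 1 to compound 3 (within the scatter). Among the compounds carrying the iodo group, the drawn configuration of this double bond therefore leaves the number unmoved, whereas removing the iodo group gave a 9.4-fold lower number from compound 1 to compound 2 (0.97 log units; beyond the scatter). The comparison is a clean one, as a single feature separates the pair: the fact that compounds 1 and 3 differ only in the configuration as drawn.

Going by these compounds, it remains open whether the double bond would matter as little in the compound with hydrogen in place of iodo, where the number is already lower, so the finding so far rests on one pair carrying a single group. On these data alone, it is also open how the number would respond if an amine or a carboxylic acid stood in place of the iodo group, and whether either would make the configuration of the double bond count.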